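The source may hold more compounds than are shown below. What is called first, only, known or untested is meant among the compounds shown, and "the series" means these compounds.

Compounds measured so far:

Compound 1 `Cc1ccc(-c2cn(C/C=C3\OC(=O)C(OCc4ccccc4)=C3OCc3ccccc3)nn2)cc1` — in a functional assay on A549 cells (Homo sapiens) for antiproliferative activity, read by MTT assay, with a stated time of 72 h (a lower number here means a stronger inhibitor, a higher number a weaker inhibitor), compound 1 gives > 100000 nM, which is a limit of the assay and not a number.
Compound 2 `COc1ccccc1-c1cn(C[C@H](O)[C@H]2OC(=O)C(OCc3ccccc3)=C2OCc2ccccc2)nn1` — in this assay compound 2 gives > 100000 nM, again a limit.
Compound 3 `COc1ccccc1-c1cn(C/C=C2\OC(=O)C(OCc3ccccc3)=C2OCc2ccccc2)nn1` — in this assay compound 3 gives > 100000 nM, again a limit.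

Compound 2 therefore stands at a limit, not at a measured value, and the same holds for the other two values shown (the limit of > 100000 nM in this assay, at which 3 of the 3 values shown sit). Going by the values given here, the one step that can be traced, from compound 1 to compound 3 a step that the two limits leave unreadable from compound 1 to compound 3, passes between two limits and its size cannot be read.

Compound 4 `O=C1O[C@H]([C@@H](O)Cn2cc(-c3cc(F)cc(F)c3)nn2)C(OCc2ccccc2)=C1OCc1ccccc1` has not yet been measured. It differs from compound 2 in one place: 3,5-difluorophenyl in place of 2-methoxyphenyl on an aromatic carbon. Among the compounds with values here, no measured step bears directly on this change, and the only comparable step between two aryl groups on the same ring carbon was unreadable. The expectation is therefore no step beyond the scatter from compound 2 to compound 4 a number no higher from compound 2 to compound 4 (the limit leaves the size open), and compound 4 is expected to sit at 100000 nM, in the range 40000 nM to 300000 nM, most likely again as a limit.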

Compound 4, half-maximal inhibitory concentration: 41200 nM
Beside the measured number, compound 4's estimate is 2.4-fold (0.39 log units) above it, and the stated range covers the measured number.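

In this assay, 3,5-difluorophenyl in place of 2-methoxyphenyl on this aromatic carbon of the five-membered ring gives an at least 2.4-fold lower number from compound 2 to compound 4 (0.38 log units; beyond the scatter). Going by these compounds alone, this shows that the aryl group at this position can move the read-out, whereas the one earlier aryl step passed between two limits and could not be read. Compound 4 is the only compound shown with a number rather than a limit: the limit of > 100000 nM in this assay, at which 3 of the 4 values shown sit.

The single change removes the methoxy group and brings in the two fluorines together, and the compounds shown do not separate these two parts of the change. Also open, going by these compounds, is how a phenyl group carrying one fluorine, a chlorine or an amine would read at this position.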